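A few compounds are considered here, and "the series" means these few. Any claim that something is new, unique, unknown or untested is made for them only; others in the source may bear on it.

Measured in an ADME assay on HeLa cells (Homo sapiens) for cytotoxicity, read by MTT assay, with a stated time of 2 days; on this read-out lower numbers stand for higher toxicity in this test and higher numbers for lower toxicity in this test:
- compound 1 `CCOC(=O)c1cc2ccc(Oc3ccnc(C(=O)NC)c3)cc2s1` gives > 100000 nM
- compound 2 `CNC(=O)c1cc(Oc2ccc3cc(C(=O)OC(C)C)n(C)c3c2)ccn1` gives 46100 nM
- compound 3 `CNC(=O)c1cc(Oc2ccc3ccc(C(=O)OC)cc3c2)ccn1` gives 33800 nM

The entry for compound 1 is a limit of the assay and not a number. Compound 3 at 33800 nM lies within the usual scatter of compound 2 at 46100 nM.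

Compound 4 `CCOC(=O)c1ccc2ccc(Oc3ccnc(C(=O)NC)c3)cc2c1` replaces the methoxycarbonyl of compound 3 with ethoxycarbonyl: methyl in place of hydrogen on a saturated chain carbon bound to an oxygen next to a carbonyl group.

For the measured compounds named here, no measured pair shows this change, so no step beyond the scatter is expected in this assay. The estimated step is a 1.3-fold higher number from compound 3 to compound 4 (0.12 log units; within the scatter). For compound 4 the expected value is 45000 nM, with an estimated range of 20000 nM to 100000 nM.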

Compound 4, half-maximal cytotoxic concentration: 13200 nM
Estimate against measurement, compound 4: 3.4-fold (0.53 log units) above; the measured number lies below the stated range.
By their numbers in this assay, from the lowest: compound 4; then compounds 3 and 2 (each within the scatter of the next). At a limit, above all of these: compound 1.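

Methoxycarbonyl to ethoxycarbonyl gives a 2.6-fold lower number from compound 3 to compound 4 (0.41 log units; beyond the scatter) in this assay, the first single-place change readable in this series. One added methyl on the saturated chain carbon bound to an oxygen next to a carbonyl group is thus enough to move this read-out beyond the scatter, toward higher toxicity in this test. Nothing at hand accounts for this step. On these data alone, whether a longer chain, such as propyl, on this oxygen extends the shift stays open, as does the outcome with a carboxylic acid in place of the ester.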